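A few compounds are considered here, and "the series" means these few. Any claim that something is new, unique, unknown or untested is made for them only; others in the source may bear on it.

In a functional assay on L1210 cells (Mus musculus) for antiproliferative activity, with a stated time of 48 h (a higher number here means a weaker inhibitor, a lower number a stronger inhibitor), compound 1 `Nc1ccc(/C=C/C(=O)c2ccc(Br)cc2)cc1`, which carries a bromo group, gives 90000 nM. Compound 2 `Nc1ccc(/C=C/C(=O)c2ccc(I)cc2)cc1`, with iodo in that place, gives 50000 nM, and compound 3 `COc1ccc(C(=O)/C=C/c2ccc(N)cc2)cc1`, with methoxy there, gives 160000 nM. Compound 3 is clearly a weaker inhibitor than only one of the other two, as the data show a 3.2-fold higher number from compound 2 to compound 3 (0.51 log units; beyond the scatter). The other comparison gives a 1.8-fold higher number from compound 1 to compound 3 (0.25 log units; within the scatter), so those two values cannot be told apart. The exchange of bromo for iodo gives a 1.8-fold lower number from compound 1 to compound 2 (0.26 log units; within the scatter).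

The next compound, compound 4 `CCOc1ccc(C(=O)/C=C/c2ccc(N)cc2)cc1`, differs from compound 3 by one small change: methyl in place of hydrogen on a saturated chain carbon bound to an oxygen on an aromatic ring. This is methyl in place of hydrogen on a saturated chain carbon bound to an oxygen on an aromatic ring, which turns methoxy into ethoxy. For the measured compounds named here, no measured pair shows this change directly. The nearest evidence is the three exchanges of a whole group on the aromatic carbon, and the largest of these is only modest, at a 3.2-fold higher number from compound 2 to compound 3 (0.51 log units; beyond the scatter). Lengthening methoxy by one carbon is a smaller edit, so no step beyond the scatter is expected in this assay. The expected result is a 1.2-fold lower number from compound 3 to compound 4 (0.09 log units; within the scatter). Compound 4 is therefore estimated at 130000 nM, with an expected range from 65000 nM to 260000 nM.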

Compound 4, half-maximal inhibitory concentration: 21000 nM
Beside the measured number, compound 4's estimate is 6.2-fold (0.79 log units) above it; the whole stated range lies above it.
By their numbers in this assay, from the lowest: compound 4; then compounds 2, 1 and 3 (each within the scatter of the next, the first and the last beyond it).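

At the saturated chain carbon bound to an oxygen on an aromatic ring, a single added methyl turns methoxy into ethoxy, and in this assay this small edit gives a clear change (a 7.6-fold lower number from compound 3 to compound 4 (0.88 log units; beyond the scatter)). The earlier compounds shown here showed only exchanges of a whole group on the aromatic carbon, and compound 1 could not be told apart from either compound 2 or compound 3, whereas ethoxy also separates from iodo (a 2.4-fold lower number from compound 2 to compound 4 (0.38 log units; beyond the scatter)) and from bromo (a 4.3-fold lower number from compound 1 to compound 4 (0.63 log units; beyond the scatter)), which makes compound 4 the strongest inhibitor of these four. Methoxy and ethoxy therefore cannot be treated as interchangeable here, and no measurement shown offers an explanation for the difference between them.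

The compounds shown leave open whether a longer chain, such as propoxy or butoxy, would continue this trend or reverse it, so a single step cannot define a trend with chain length. They also leave open how a hydroxy group on the same aromatic carbon, which lacks the saturated chain altogether, would compare with methoxy and ethoxy in this assay.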